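Methyl for fluoro on a compound at the limit

The source may report more compounds than this note shows. Statements on the series, on what has been measured and on what is new or still open speak of the compounds shown alone.

Compound 1 `C#CCn1c(=O)c(C=O)cc2cc(Cl)ccc21` gives > 100000 nM
Compound 2 `C#CCn1c(=O)c(C=O)cc2cc(F)ccc21` gives > 100000 nM

Both compounds were tested in a functional assay on A549 cells (Homo sapiens) for cytotoxicity, read by MTT assay, with a stated time of 24 h (on this read-out higher numbers stand for weaker inhibition and lower numbers for stronger inhibition), and differ in one group on the shared core. In this test compound 2 gives > 100000 nM as a limit of the assay, not as a number. Compound 1 gives > 100000 nM as a limit too. All that has been measured so far is the limit of > 100000 nM in this assay, at which 2 of the 2 values shown sit, and nothing finer.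

Compound 3 `C#CCn1c(=O)c(C=O)cc2cc(C)ccc21` keeps the core of compound 2 and changes a single group: methyl in place of fluoro on an aromatic carbon. Here methyl takes the place of fluoro on an aromatic carbon.

Going by the values given here, the one measured step that bears on this is also a swap of one group on an aromatic carbon. No size can be carried over from it, because a step that the two limits leave unreadable from compound 1 to compound 2 offers none to scale from. Compound 1 and compound 2 share the same limit, so compound 3 is expected to stay near it, with no step beyond the scatter and no firm direction in this assay. The estimated step that the limit leaves unreadable from compound 2 to compound 3 is expected to be small.

Compound 3 is expected at 120000 nM, with an estimated range from 40000 nM to 300000 nM in this test, and it may well be reported only as a limit.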

Compound 3, half-maximal inhibitory concentration: > 100000 nM
Compound 3: a limit, no number (the forecaster's own chance of this, stated with the estimate: 80%); the middle value lies beyond the limit too.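

Compound 1, compound 2 and compound 3 all end at a limit of the assay and not at a number, so no step among them can be read: the limit of > 100000 nM in this assay, at which 3 of the 3 values shown sit.

From the compounds shown here alone, whether chloro, fluoro and methyl on this aromatic carbon differ at all in this assay stays open, as does which change to the shared core would give a measurable value.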